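This account rests on a few compounds, and the source may have more. Where it says the series, first, only, none or still open, it means among the compounds named here.

Measured compounds:
compound 1, `O=[N+]([O-])c1cn2c(n1)OC[C@@H](OCc1c(F)cc(-c3ccc(OC(F)(F)F)cc3)cc1F)C2` — 95%
compound 2, `O=[N+]([O-])c1cn2c(n1)OC[C@@H](OCc1ccc(-c3ccc(OC(F)(F)F)cc3)cc1C(F)(F)F)C2` — 100%
compound 3, `O=[N+]([O-])c1cn2c(n1)OC[C@@H](COc1ccc(OC(F)(F)F)cc1)C2` — 91%

In an ADME assay (liver) for metabolic stability, with Liver microsome (Homo sapiens) as the target, using microsomes, with a stated time of 1 h (a higher number here means that more of the compound is left, a lower number that less of the compound is left), compound 1 gives 95%, compound 2 gives 100% and compound 3 gives 91%. The gaps from compound 3 to compound 1 and to compound 2 both fall within the usual scatter of this assay, so the three values cannot be told apart.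

Compound 4, `O=[N+]([O-])c1cn2c(n1)OC[C@H](COc1ccc(OC(F)(F)F)cc1)C2`, has not yet been measured. Its relation to compound 3 is this: the two compounds have the same atoms and bonds and differ only in configuration as drawn: 1 of 1 stereo elements differ; a stereocentre at a saturated ring carbon is drawn R in compound 3 and S in compound 4. Within the data shown here, no measured pair in this set shows such a change, so the size of the step is open; with the atoms and bonds unchanged, no shift beyond the scatter in this assay is expected in either direction.

Compound 4 is therefore expected to give 90%, within 75% to 100%, which means an expected step of a number 1 percentage points lower from compound 3 to compound 4 (within the scatter).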

Compound 4, percent of the compound remaining: 90%
Beside the measured number, compound 4's estimate shows no gap at the digits printed; the range from low to high includes it.
By their numbers in this assay, from the lowest: compounds 4, 3, 1 and 2 (each within the scatter of the next).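

In this assay, inverting the stereocentre at the saturated ring carbon gives a number 1 percentage points lower from compound 3 to compound 4 (within the scatter), the first step read at this position. With this side chain, the drawn R and S forms therefore cannot be told apart in this assay. The step reflects configuration alone, and the ground for that is: the fact that compounds 3 and 4 differ only in the configuration as drawn

From the compounds shown here alone, whether configuration at this carbon matters as little with the side chains of compound 1 and compound 2 stays open. So does the outcome for a side chain carrying an amine or a carboxylic acid.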